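Moving from 1-methylhexyl to 1-propylbutyl on a shared core

The source may report more compounds than this note shows. Statements on the series, on what has been measured and on what is new or still open speak of the compounds shown alone.

Compound 1 `COc1cc2cc(C#N)ccc2c(OC)c1Oc1cc(NCC(C)C)nc(Nc2ccc(C#N)cc2)n1` and compound 2 `CCCCCC(C)Nc1cc(Oc2c(OC)cc3cc(C#N)ccc3c2OC)nc(Nc2ccc(C#N)cc2)n1` share a core and differ in the group on a nitrogen on an aromatic ring. In an ADME assay on MT4 cells (Homo sapiens) for cytotoxicity, read by MTT assay, with a stated time of 5 days (a lower number here means that less compound is tolerated, a higher number that more compound is tolerated), compound 1 gives > 125000 nM, which is a limit of the assay and not a number. Compound 2 gives > 125000 nM, which is also a limit and not a number. Compound 2 therefore has no exact position, and the whole record so far is the limit of > 125000 nM in this assay, at which 2 of the 2 values shown sit. Going by the values given here, the only measured step, a step that the two limits leave unreadable from compound 1 to compound 2, offers no size to build on.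

Compound 3 `CCCC(CCC)Nc1cc(Oc2c(OC)cc3cc(C#N)ccc3c2OC)nc(Nc2ccc(C#N)cc2)n1` keeps the same core and carries 1-propylbutyl in place of 1-methylhexyl on a nitrogen on an aromatic ring, (1-propylbutyl in place of 1-methylhexyl on a nitrogen on an aromatic ring). The two chains have the same atoms, joined differently. With no readable step to draw on, the expectation rests on compound 2 at > 125000 nM, a limit. In this assay the estimated step is a number no higher from compound 2 to compound 3 (the limit leaves the size open), so nothing beyond the usual scatter is expected. For compound 3 the expected value is 125000 nM, with an estimated range from 50000 nM to 250000 nM, and it may well be reported only as a limit.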

Compound 3, half-maximal cytotoxic concentration: > 125000 nM
Compound 3 was reported as a limit; the forecaster's own chance of this, stated with the estimate: 85%; the middle value lies on the limit itself.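

No step among compound 1, compound 2 and compound 3 can be read, since each value is a limit and not a number: the limit of > 125000 nM in this assay, at which 3 of the 3 values shown sit.

The compounds shown leave open what concentration of each one is needed to harm the cells, and whether swapping among isobutyl, 1-methylhexyl and 1-propylbutyl changes the result in this assay at all.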